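Estimating Compound 4 from Compound 3 in Lipophilicity

A few compounds are considered here, and "the series" means these few. Any claim that something is new, unique, unknown or untested is made for them only; others in the source may bear on it.

Compound 1 `NC(=O)C[C@H](NC(=O)c1ccc(C#Cc2ccccc2)cc1)C(=O)NO`: 1
Compound 2 `COCCNC(=O)C[C@H](NC(=O)c1ccc(C#Cc2ccccc2)cc1)C(=O)NO`: 2
Compound 3 `CC(NC(=O)c1ccc(C#Cc2ccccc2)cc1)C(=O)NO`: > 3

All three were measured in a physicochemical assay for lipophilicity; a higher number here means a more lipophilic compound, a lower number a more polar compound. In this assay compound 1 gives 1 and compound 2 gives 2. For the measured compounds named here, the only measured step between compounds differing in one place is a number 1.00 log units higher from compound 1 to compound 2 (beyond the scatter), with 2-methoxyethyl in place of hydrogen on an amide-type nitrogen. For compound 3 this assay reports no number but a limit, > 3, so compound 3 sits at the limit of > 3 in this assay, at which 1 of the 3 values shown sits.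

Compound 4, `O=C(NC1(C(=O)NO)CCC1)c1ccc(C#Cc2ccccc2)cc1`, has not yet been measured. It differs from compound 3 by 1-(hydroxycarbamoyl)cyclobutyl in place of 1-(hydroxycarbamoyl)ethyl on an amide-type nitrogen. Going by the values given here, the single measured step, a number 1.00 log units higher from compound 1 to compound 2 (beyond the scatter), concerns another place and another group and does not match this change; it shows only that enlarging a substituent on an amide-type nitrogen moved the value upward there. Compound 4 is therefore expected to lie at 3.6, between 3.1 and 4.2, most likely reported again as a limit. The step that the limit leaves unreadable from compound 3 to compound 4 is expected to be small and upward, if a number is returned at all.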

Compound 4, distribution coefficient: > 3
Compound 4 was reported as a limit; the forecaster's own chance of this, stated with the estimate: 75%; the middle value is on the limit's open side.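

For the compounds shown here, compound 3 and compound 4 are both reported in this assay only as limits, so no step between them can be read: the limit of > 3 in this assay, at which 2 of the 4 values shown sit. The compounds shown leave open whether 1-(hydroxycarbamoyl)cyclobutyl in place of 1-(hydroxycarbamoyl)ethyl on an amide-type nitrogen changes the value at all.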